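Phenyl to pyridin-3-yl on the alkyne of compound 3

The source may report more compounds than this note shows. Statements on the series, on what has been measured and on what is new or still open speak of the compounds shown alone.

Measured so far:
compound 1, `COc1cccc(C#Cc2ccc3c(n2)CCN(C)C3=O)c1`: 293 nM
compound 2, `CN1CCc2nc(C#Cc3ccccn3)ccc2C1=O`: 184 nM
compound 3, `CC(C)N1CCc2nc(C#Cc3ccccc3)ccc2C1=O`: 706 nM

In a functional assay on HEK293 cells for negative allosteric modulation of metabotropic glutamate receptor 5 (Homo sapiens), read by FLIPR and calcium flux (on this read-out higher numbers stand for weaker inhibition and lower numbers for stronger inhibition), compound 3 gives 706 nM, the highest of the three numbers. Compound 1, which in this assay gives 293 nM, sits nearest to it, and the gap between them lies beyond the scatter. Compound 2, with 184 nM in this assay, lies furthest from compound 3, again beyond the scatter. Compound 3 therefore stands as the weakest inhibitor among the three measured compounds.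

Compound 4, `CC(C)N1CCc2nc(C#Cc3cccnc3)ccc2C1=O`, differs from compound 3 in one place: pyridin-3-yl in place of phenyl on a triple-bonded carbon. For the measured compounds named here, no step between two measured compounds isolates this change, so the expectation rests on the shared core and on the spread of the three numbers. Compound 2 shows that an aromatic ring carrying a nitrogen on the alkyne is compatible with a low number in this assay, but compound 2 also carries a different substituent on the amide nitrogen, so it does not settle the question. Compound 4 is expected to show a step of a 1.2-fold lower number from compound 3 to compound 4 (0.07 log units; within the scatter) from compound 3, which is within the scatter. Compound 4 is estimated at 600 nM, with a range from 250 nM to 1500 nM.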

Compound 4, half-maximal inhibitory concentration: "not active" (no number reported)
Compound 4 has no reported number here; the estimate stays without a comparison.
By their numbers in this assay, from the lowest: compounds 2 and 1 (each within the scatter of the next); then compound 3.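

In this assay, for the compounds shown here, compound 4 is reported as not active, without a number, so no step from compound 3 to compound 4 can be read. The compounds shown leave open how pyridin-3-yl in place of phenyl on a triple-bonded carbon would change the number on any other measured pair. No measurement shown here bears on this result.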